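An aryl swap from compound 2 to compound 3

This account rests on a few compounds, and the source may have more. Where it says the series, first, only, none or still open, it means among the compounds named here.

Going by the values given here, in a functional assay on HT-29 cells (Homo sapiens) for antiproliferative activity, read by sulforhodamine B assay, with a stated time of 72 h (a higher number here means a weaker inhibitor, a lower number a stronger inhibitor), compound 2 `S=C(N/N=C/c1ccc2ccccc2n1)Nc1ccc(Br)cc1` gives 54400 nM, the only numeric value so far. Compound 1 `COc1ccccc1NC(=S)N/N=C/c1ccc2ccccc2n1` gives > 100000 nM, which is a limit of the assay and not a number. Among the compounds with values here, the single measured step, an at least 1.8-fold lower number from compound 1 to compound 2 (0.26 log units; that floor lies within the scatter), puts 4-bromophenyl in place of 2-methoxyphenyl on an amide-type nitrogen. It rests on that limit, and its floor lies within the scatter.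

Compound 3 `S=C(N/N=C/c1ccc2ccccc2n1)Nc1cccc(Cl)c1` changes the same place: 3-chlorophenyl in place of 4-bromophenyl on an amide-type nitrogen, with 3-chlorophenyl in place of 4-bromophenyl. The measured step sets no firm size and no direction for this change, so no shift beyond the scatter is expected in this assay. The expected size is a 1.4-fold lower number from compound 2 to compound 3 (0.13 log units; within the scatter). Compound 3 is estimated at 40000 nM, with an expected range of 11000 nM to 100000 nM.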

Compound 3, half-maximal inhibitory concentration: 48100 nM
Estimate against measurement, compound 3: 1.2-fold (0.08 log units) below; the measured number falls inside the stated range.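

In this assay, going by these compounds alone, the aryl group on the amide-type nitrogen now has a first pair of numbers behind it (a 1.1-fold lower number from compound 2 to compound 3 (0.05 log units; within the scatter)), and 3-chlorophenyl and 4-bromophenyl are not told apart at this position. Within the data shown here, the other new step (an at least 2.0-fold lower number from compound 1 to compound 3 (0.31 log units; beyond the scatter)) is the first at this place to clear the scatter, though only as a floor. From the compounds shown here alone, compound 1 gives > 100000 nM, which is a limit of the assay and not a number, and the true size of that step stays unknown: the limit of > 100000 nM in this assay, at which 1 of the 3 values shown sits.

The swap from 4-bromophenyl to 3-chlorophenyl changes the halogen and its numbered place together, and these values do not separate the two. Also open, going by these compounds, is whether an amine or a carboxylic acid on this aryl ring, or a longer alkyl chain in its stead, would move the number beyond the scatter.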